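Swapping the group on the carbonyl carbon: estimate for compound 3

The source may hold more compounds than are shown below. What is called first, only, known or untested is meant among the compounds shown, and "the series" means these compounds.

compound 1 `COCc1ccc(C(=O)NCc2ccc3cc(C(=O)NO)sc3c2F)o1` at 310 nM
compound 2 `O=C(NCc1ccc2cc(C(=O)NO)sc2c1F)c1ccc[nH]1` at 300 nM

Both values come from a functional assay on HCT-116 cells (Homo sapiens) for antiproliferative activity, read by resazurin assay, with a stated time of 5 days (on this read-out lower numbers stand for stronger inhibition and higher numbers for weaker inhibition), and are all there is so far. Among the measured compounds shown here, the one measured step (a 1.0-fold lower number from compound 1 to compound 2 (0.01 log units; within the scatter)) leaves compound 2 level with the only other measured compound, so no ranking of the two is possible. Compound 3 `COc1ccc(C(=O)NCc2ccc3cc(C(=O)NO)sc3c2F)cc1` is the next case (4-methoxyphenyl in place of 1H-pyrrol-2-yl on a carbonyl carbon) and puts 4-methoxyphenyl in place of 1H-pyrrol-2-yl on a carbonyl carbon. For the measured compounds named here, that same measured step is the only one bearing on this change, and it stayed within the scatter. Going by these compounds, it covers just two groups, each with a five-membered aromatic ring, so a six-membered aromatic ring of carbon only is untested here and the evidence is thin. No step beyond the scatter is expected in this assay in either direction. The estimated step (no change at the digits printed from compound 2 to compound 3 (within the scatter)) is therefore close to nil, with a wide margin. For compound 3 the estimated value is 300 nM with an expected range from 120 nM to 750 nM on this read-out.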

Compound 3, half-maximal inhibitory concentration: 50 nM
Compound 3: the middle estimate sits 6.0-fold (0.78 log units) above what was measured; the measured number lies below the stated range.
By their numbers in this assay, from the lowest: compound 3; then compounds 2 and 1 (each within the scatter of the next).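

In this assay the 4-methoxyphenyl group gives a 6.0-fold lower number from compound 2 to compound 3 (0.78 log units; beyond the scatter) and a 6.2-fold lower number from compound 1 to compound 3 (0.79 log units; beyond the scatter) and so stands apart from the two groups with a five-membered aromatic ring, which had stayed within the scatter of each other. The position on a carbonyl carbon whose other neighbours are an amide-type nitrogen is therefore not indifferent to the group it carries, and the flat result from compound 1 and compound 2 holds only for those two groups. The change from compound 2 to compound 3 alters the ring size, the ring atoms, the methoxy substituent and the donor and acceptor counts all at once, and no measurement shown here accounts for the step.

Still open, going by these compounds, is whether the step belongs to the six-membered aromatic ring of carbon only or to its methoxy group, a question that a plain phenyl group on the carbonyl carbon would address. Also open, on these data alone, is how this read-out responds when the methoxy group on that ring gives way to an amine, a carboxylic acid or a longer alkoxy chain.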